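A few compounds are considered here, and "the series" means these few. Any claim that something is new, unique, unknown or untested is made for them only; others in the source may bear on it.

Values measured in a functional assay on HL-60 cells (Homo sapiens) for inhibition; a higher number here means a weaker inhibitor of growth, a lower number a stronger inhibitor of growth:
compound 1 `C=C(C)C(=O)c1ccc(OCc2nc(-c3ccccc3)no2)cc1C`: 6700 nM
compound 2 `C=C(C)C(=O)c1ccc(OCc2nc(-c3ccc(F)cc3)no2)cc1C`: 4600 nM
compound 3 `C=C(C)C(=O)c1ccc(OCc2nc(-c3ccc([N+](=O)[O-])cc3)no2)cc1C`: 6100 nM

Compound 1 cannot be ranked against the other two, since a 1.5-fold lower number from compound 1 to compound 2 (0.16 log units; within the scatter) and a 1.1-fold lower number from compound 1 to compound 3 (0.04 log units; within the scatter) both stay within the scatter, as does a 1.3-fold higher number from compound 2 to compound 3 (0.12 log units; within the scatter). Compound 4 `C=C(C)C(=O)c1ccc(OCc2nc(-c3ccccc3)no2)cc1Cl` has not yet been measured. It differs from compound 1 by chloro in place of methyl on an aromatic carbon, ortho to a (1-methylethenyl)carbonyl group. Among the measured compounds shown here, none of the measured steps changes this carbon, as they swap hydrogen, fluoro and nitro at a different place. They are therefore only an indirect guide, showing a series whose values stayed close under those swaps. For the measured compounds named here, with no direct precedent, no step beyond the scatter is expected in this assay, though a real shift in either direction cannot be ruled out. The estimated step is a 1.2-fold lower number from compound 1 to compound 4 (0.09 log units; within the scatter). For compound 4 the estimated value is 5500 nM, with an expected range from 2300 nM to 13000 nM.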

Compound 4, concentration for 50% growth inhibition: 5400 nM
The estimate for compound 4 lay 1.0-fold (0.01 log units) above the measured number, and the stated range covers the measured number.
By their numbers in this assay, from the lowest: compounds 2, 4, 3 and 1 (each within the scatter of the next).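

In this assay, chloro in place of methyl on the aromatic carbon ortho to a (1-methylethenyl)carbonyl group gives a 1.2-fold lower number from compound 1 to compound 4 (0.09 log units; within the scatter) and so cannot be told apart from no change. Among the compounds shown here, compounds 1, 2 and 3 differ from one another only at a different place, so this pair adds the first reading at this carbon: here, methyl and chloro give values that this assay cannot separate. No measurement shown helps to interpret this result.

Going by these compounds, whether a methoxy group, an amine or a longer chain at this carbon would move the number beyond the scatter remains open. Also open, on these data alone, is whether chloro at this carbon would give a similar result alongside the fluoro of compound 2 or the nitro of compound 3.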